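This account rests on a few compounds, and the source may have more. Where it says the series, first, only, none or still open, it means among the compounds named here.

Measured compounds:
- compound 1 `C=CC1=C(C(=O)Nc2ccccc2)C(c2ccc(Cl)c(Cl)c2)OC1`, which in a functional assay on QGY7701 cells (Homo sapiens) for cytotoxicity, read by MTT assay, with a stated time of 24 h (a higher number here means a weaker inhibitor, a lower number a stronger inhibitor), gives only a limit of the assay, > 100000 nM.
- compound 2 `C=CC1=C(C(=O)Nc2ccccc2)C(c2ccc(F)cc2)OC1`, which in this assay gives 46700 nM.
- compound 3 `C=CC1=C(C(=O)NCc2ccccc2)C(c2ccc(F)cc2)OC1`, which in this assay gives 67600 nM.

Compound 3 differs from compound 2 by benzyl in place of phenyl on an amide-type nitrogen, and the step of a 1.4-fold higher number from compound 2 to compound 3 (0.16 log units; within the scatter) stays within the scatter. Compound 1 differs from compound 2 by 3,4-dichlorophenyl in place of 4-fluorophenyl on a saturated ring carbon, and there the step of an at least 2.1-fold higher number from compound 2 to compound 1 (0.33 log units; beyond the scatter); its size is only a lower bound because of the limit of > 100000 nM in this assay, at which 1 of the 3 values shown sits.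

Compound 4 `C=CC1=C(C(=O)NCc2ccccc2)C(c2ccc(Cl)c(Cl)c2)OC1` has not yet been measured in this assay. It differs from compound 3 by 3,4-dichlorophenyl in place of 4-fluorophenyl on a saturated ring carbon, the same kind of change as that from compound 2 to compound 1; the surroundings differ only in that the change sits next to the ring atom that bears a large group in one case and a group of 9 heavy atoms in the other. Within the data shown here, since the one measured instance of this change, an at least 2.1-fold higher number from compound 2 to compound 1 (0.33 log units; beyond the scatter), ran out of the assay's range, compound 4 is expected to show a step of a 2.4-fold higher number from compound 3 to compound 4 (0.37 log units; beyond the scatter) and will likely again give only a limit. Compound 4 is therefore estimated at 160000 nM, between 70000 nM and 400000 nM.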

Compound 4, half-maximal inhibitory concentration: > 100000 nM
Compound 4: a limit, no number; the forecaster's own chance of this, stated with the estimate: 70%; the middle value is on the limit's open side.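

In this assay compound 4 gives only a limit of the assay, > 100000 nM. On the benzyl amide core, 3,4-dichlorophenyl in place of 4-fluorophenyl gives an at least 1.4-fold higher number from compound 3 to compound 4 (0.17 log units; that floor lies within the scatter), which agrees with a weakening carried over from the phenyl amide core but does not by itself establish one. Going by these compounds, the size of the change on each core remains unknown, and the two steps can be compared only as floors: the same change on two cores in this assay, an at least 2.1-fold higher number (0.33 log units; beyond the scatter) from compound 2 to compound 1 and an at least 1.4-fold higher number (0.17 log units; that floor lies within the scatter) from compound 3 to compound 4; the limit leaves it open whether they differ.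

The effect of benzyl in place of phenyl on an amide-type nitrogen cannot be read on the 3,4-dichlorophenyl core, as both values there are limits: the limit of > 100000 nM in this assay, at which 2 of the 4 values shown sit. The compounds shown also leave open how the series would read in this assay with an amine or a carboxylic acid on the aromatic ring of the amide group, or with a longer chain in place of the vinyl group.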